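Swapping the Nitro-Bearing Ring for a Dichlorophenyl

This account rests on a few compounds, and the source may have more. Where it says the series, first, only, none or still open, it means among the compounds named here.

Measured compounds:
compound 1 `O=C(/C=C/c1ccc(Oc2ncnc3ccc(Cl)cc23)cc1)/C=C/c1cc([N+](=O)[O-])ccc1Cl` — 86.7%
compound 2 `O=C(/C=C/c1ccc(Oc2ncnc3ccc(Cl)cc23)cc1)/C=C/c1c(Cl)cccc1Cl` — 61.7%
compound 3 `O=C(/C=C/c1ccc(Cl)c([N+](=O)[O-])c1)/C=C/c1ccccc1Oc1ncnc2ccc(Cl)cc12` — 70.2%

Of the compounds shown here, three have been tested in a functional assay on MGC-803 cells (Homo sapiens) for inhibition, read by MTT assay, with a stated time of 72 h, tested at 10 uM; a lower number here means less inhibition of growth, a higher number more inhibition of growth at the concentration tested. Compound 1 gives 86.7%, the highest of the three numbers. Its nearest neighbour, compound 3, gives 70.2%, and compound 2 gives 61.7%; both lie below compound 1 beyond the usual scatter.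

Compound 4 `O=C(/C=C/c1ccc(Oc2ncnc3ccc(Cl)cc23)cc1)/C=C/c1ccc(Cl)c(Cl)c1` has not yet been measured. It differs from compound 1 in one place: 3,4-dichlorophenyl in place of 2-chloro-5-nitrophenyl on a double-bonded chain carbon bound to a double-bonded chain carbon. Within the data shown here, one measured step bears directly on this change, since it also puts a dichlorophenyl in place of the 2-chloro-5-nitrophenyl at the same position: a number 25 percentage points lower from compound 1 to compound 2 (beyond the scatter). Compound 3 carries the same two rings as compound 1 on swapped arms, so only its value speaks, and it too sits below compound 1.

On that basis a downward step is expected, a number 18.7 percentage points lower from compound 1 to compound 4 (beyond the scatter), of a size in the modest range. Compound 4 is therefore estimated at 68%, within a range from 50% to 85%.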

Compound 4, percent growth inhibition at one concentration: 50.5%
Estimate against measurement, compound 4: 17.5 percentage points above; the measured number falls inside the stated range.
By their numbers in this assay, from the lowest: compound 4; then compounds 2 and 3 (each within the scatter of the next); then compound 1.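

In this assay, changing to 3,4-dichlorophenyl gives a number 36.2 percentage points lower from compound 1 to compound 4 (beyond the scatter) and is a large drop, so the loss at this position now appears with two different dichlorophenyl groups, not with the 2,6-dichlorophenyl alone. The two dichlorophenyl groups also differ from each other: the change between them gives a number 11.2 percentage points lower from compound 2 to compound 4 (beyond the scatter) and shows that the arrangement of the two chlorines on this ring affects the number, not just the departure of the 2-chloro-5-nitrophenyl. No supporting measurement is available to explain either drop.

On these data alone, whether the nitro group or the chlorine of the 2-chloro-5-nitrophenyl matters more at this position remains open. So does the effect of a phenyl ring carrying an amine or a carboxylic acid at this same place.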